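Urea Series: Expected Solubility of a Fluorophenyl Analogue

A few compounds are considered here, and "the series" means these few. Any claim that something is new, unique, unknown or untested is made for them only; others in the source may bear on it.

Measured compounds:
compound 1, `COc1ccc(NC(=O)Nc2cc(C)nc3ccccc23)cc1F`, 2700 nM in a physicochemical assay for solubility, at pH 7.4; on this read-out lower numbers stand for lower solubility and higher numbers for higher solubility
compound 2, `Cc1cc(NC(=O)Nc2ncccc2C)c2ccccc2n1`, 1300 nM in this assay
compound 3, `Cc1cc(NC(=O)Nc2ccccc2C(F)(F)F)c2ccccc2n1`, 3800 nM in this assay

Among the three measured compounds, compound 2 gives the lowest number in this assay. Compound 1 sits nearest to it, and compound 3 furthest; both of those gaps lie beyond the usual scatter of repeated measurements, so compound 2 is indeed the least soluble of the three on these numbers.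

Compound 4, `Cc1cc(NC(=O)Nc2ccc(F)cc2)c2ccccc2n1`, has not yet been measured. It differs from compound 2 in one place: 4-fluorophenyl in place of 3-methylpyridin-2-yl on an amide-type nitrogen. For the measured compounds named here, no step between measured compounds in this assay matches such a change, so the expectation rests only on the spread of the three values, which all fall within a narrow band. The step of a 1.5-fold higher number from compound 2 to compound 4 (0.19 log units; within the scatter) is estimated to be modest and upward, in keeping with compound 1 and compound 3 both lying above compound 2. Compound 4 is therefore expected to give about 2000 nM in this assay, within a range from 600 nM to 6000 nM.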

Compound 4, solubility: 3700 nM
Compound 4: middle estimate off by 1.9-fold (0.27 log units), on the low side; the measured number falls inside the stated range.
By their numbers in this assay, from the lowest: compound 2; then compounds 1, 4 and 3 (each within the scatter of the next).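

In this assay, the change at this position, on an amide-type nitrogen whose other neighbour is the carbonyl carbon, now has a direct reading: 4-fluorophenyl in place of 3-methylpyridin-2-yl gives a 2.8-fold higher number from compound 2 to compound 4 (0.45 log units; beyond the scatter), a step beyond the scatter. The two groups match in heavy atoms, hydrogen-bond donors and net charge, so this step comes with a swap that takes the count of hydrogen-bond acceptors from one to none and exchanges a ring nitrogen and a methyl for a fluorine. Nothing available explains the step.

For the compounds shown here, the single step cannot show whether the ring nitrogen, the methyl or the fluorine accounts for it. Also open, going by these compounds, is how an unsubstituted phenyl, or a phenyl carrying an amine or a carboxylic acid, would read at this position.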